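Shifting fluorine within the fluorophenyl on a carbonyl carbon

The compounds below may be only part of what the source reports. "The series", "measured", "known", "first", "only" and "open" are said of these compounds alone.

Measured so far in an in vitro ADME assay on microsomes from liver (Homo sapiens) for metabolic stability; on this read-out higher numbers stand for fast clearance and lower numbers for slow clearance:
compound 1 `COc1cccc(C(=O)N2CCC(=CC(=O)N[C@@H]3CCN(Cc4ccc5cc(F)ccc5c4)C3)CC2)c1O` gives 162 mL/min/kg
compound 2 `O=C(C=C1CCN(C(=O)c2cccc(F)c2)CC1)N[C@@H]1CCN(Cc2ccc3cc(F)ccc3c2)C1` gives 459 mL/min/kg
compound 3 `COc1ccc(O)c(C(=O)N2CCC(=CC(=O)N[C@@H]3CCN(Cc4ccc5cc(F)ccc5c4)C3)CC2)c1` gives 119 mL/min/kg

Compound 2 stands highest of the three in this assay: compound 1 lies nearest to it with a 2.8-fold higher number from compound 1 to compound 2 (0.45 log units; beyond the scatter) running the other way, and compound 3 lies furthest, shown by a 3.9-fold lower number from compound 2 to compound 3 (0.59 log units; beyond the scatter). Compound 4 `O=C(C=C1CCN(C(=O)c2ccccc2F)CC1)N[C@@H]1CCN(Cc2ccc3cc(F)ccc3c2)C1` has not yet been measured. It differs from compound 2 in a single place: 2-fluorophenyl in place of 3-fluorophenyl on a carbonyl carbon.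

Neither measured step speaks directly to this change. Among the compounds with values here, both steps that touch the group on the carbonyl carbon exchange a fluorophenyl for a hydroxy-methoxyphenyl, whereas here the fluorophenyl stays and only the fluorine moves within it; no pair among compounds 1, 2 and 3 shows such a move. In the absence of a matching precedent, compound 4 is expected to sit close to compound 2, with a step of a 1.1-fold lower number from compound 2 to compound 4 (0.06 log units; within the scatter) that may well fall within the scatter. The estimate for compound 4 in this assay is 400 mL/min/kg, with a range from 200 mL/min/kg to 800 mL/min/kg.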

Compound 4, clearance: 590 mL/min/kg
The estimate for compound 4 lay 1.5-fold (0.17 log units) below the measured number, within the range that was stated.
By their numbers in this assay, from the lowest: compounds 3 and 1 (each within the scatter of the next); then compounds 2 and 4 (each within the scatter of the next).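

In this assay, within the data shown here, this is the first case in which the fluorine moves while the fluorophenyl stays on the carbonyl carbon, and a 1.3-fold higher number from compound 2 to compound 4 (0.11 log units; within the scatter) shows that 3-fluorophenyl and 2-fluorophenyl cannot be told apart at this position. The separation from the hydroxy-methoxyphenyl compounds also holds for the new isomer, with a 5.0-fold higher number from compound 3 to compound 4 (0.70 log units; beyond the scatter) and a 3.6-fold higher number from compound 1 to compound 4 (0.56 log units; beyond the scatter) both beyond the scatter. No measurement on hand gives a reason for either finding.

On these data alone, it remains open whether a plain phenyl or a pyridine ring on the same carbonyl carbon would give numbers like those of compound 2 and compound 4. As far as these compounds go, it is also open whether a hydroxy or a methoxy group alone on the phenyl ring would be enough to give numbers like those of compound 1 and compound 3.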